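This account rests on a few compounds, and the source may have more. Where it says the series, first, only, none or still open, it means among the compounds named here.

Measured compounds:
compound 1 `CCN1CCc2c(c(C)nn2C(=O)Nc2c(C)cccc2C)C1` gives 78.9%
compound 2 `CCN1CCc2c(c(C)nn2C(=O)Nc2cc(C)ccc2F)C1` gives 15%
compound 3 `CCN1CCc2c(c(C(C)(C)C)nn2C(=O)Nc2c(C)cccc2C)C1` gives 68%

In a functional assay on the whole organism (strain Swiss albino) for inhibition, with Mus musculus as the target, in the formalin test, with a stated time of 30 min, at a dose of 100 mg/kg (on this read-out lower numbers stand for less inhibition and higher numbers for more inhibition at the one dose given (going by the name of the read-out)), compound 3 stands second highest of the three numbers: compound 1 lies above it, beyond the scatter, and compound 2 lies far below it. Among the compounds with values here, the only measured step that ends at compound 3 is a number 10.9 percentage points lower from compound 1 to compound 3 (beyond the scatter), and that step touches the group on the shared core, not the ring on the amide nitrogen.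

Compound 4 `CCN1CCc2c(c(C(C)(C)C)nn2C(=O)Nc2ccc(F)cc2F)C1` differs from compound 3 in exactly that other place: 2,4-difluorophenyl in place of 2,6-dimethylphenyl on an amide-type nitrogen. Within the data shown here, no measured step changes this ring on its own, so no step bears on it directly. What the numbers do show is that compound 1, which carries 2,6-dimethylphenyl, gives 78.9%, while compound 2, which carries a different ring at the same place, gives only 15%. The drop from compound 1 to compound 2 is far larger than the scatter. Taking that as the nearest guide, a large fall in this assay is expected for compound 4, estimated as a number 48 percentage points lower from compound 3 to compound 4 (beyond the scatter). Compound 4 is therefore expected to give about 20%, most likely between 5% and 45%.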

Compound 4, a percentage reported as inhibition, in the whole organism at one dose (the size of the read-out at that dose, not a potency): 73.4%
The estimate for compound 4 lay 53.4 percentage points below the measured number, and the stated range ends below it.
By their numbers in this assay, from the lowest: compound 2; then compounds 3, 4 and 1 (each within the scatter of the next, the first and the last beyond it).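

In this assay, the change on the amide-type nitrogen comes to a number 5.4 percentage points higher from compound 3 to compound 4 (within the scatter) and so, with tert-butyl on the shared core, 2,6-dimethylphenyl is not needed at this place: 2,4-difluorophenyl serves as well on this read-out. A new ring here therefore does not have to bring a number as low as that of compound 2 at 15% in this assay, even though compound 2 also carries a fluorine on its ring; compound 2 and compound 4 differ in two places, however, so that pair cannot show which change matters. Nothing available here explains why the two rings read alike.

Within the data shown here, it remains open whether 2,4-difluorophenyl would hold up with methyl in place of tert-butyl on the shared core, which is the one comparison that would show whether the two places act independently. Also open, from the compounds shown here alone, is how a plain phenyl, a pyridine or a cyclohexyl ring on the amide-type nitrogen would read, and with only one dose given, none of these numbers says anything about potency.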